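This account rests on a few compounds, and the source may have more. Where it says the series, first, only, none or still open, it means among the compounds named here.

Compound 2 `Cc1cc(Nc2nc(NCc3ccc(C#N)cc3)nc3ccccc23)n[nH]1` gives 83 nM in an assay for inhibition of high affinity nerve growth factor receptor (Homo sapiens), read by HTRF, with a stated time of 30 min, in the presence of a further agent that is not named here (a higher number here means a weaker inhibitor, a lower number a stronger inhibitor), the lowest of the two numbers measured; compound 1 `Cc1cc(Nc2nc(NCc3ccc(Br)cc3)nc3ccccc23)n[nH]1` gives 180 nM. Compound 3 `Cc1cc(Nc2nc(NCc3ccccc3F)nc3ccccc23)n[nH]1` differs from compound 2 by 2-fluorophenyl in place of 4-cyanophenyl on a saturated chain carbon bound to a nitrogen on an aromatic ring. Going by the values given here, the only measured step, a 2.2-fold lower number from compound 1 to compound 2 (0.34 log units; beyond the scatter), swapped one group for another at the same place on this ring; none removes the cyano altogether or introduces fluorine. Losing the cyano is expected to undo some of that gain, so compound 3 is estimated to show a 1.9-fold higher number from compound 2 to compound 3 (0.29 log units; within the scatter), giving an expected value of 160 nM with a range from 60 nM to 450 nM.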

Compound 3, half-maximal inhibitory concentration: 110 nM
Estimate against measurement, compound 3: 1.5-fold (0.16 log units) above; measured number inside the range.
By their numbers in this assay, from the lowest: compounds 2, 3 and 1 (each within the scatter of the next, the first and the last beyond it).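

Swapping 4-cyanophenyl for 2-fluorophenyl removes the nitrile and changes where the ring carries its group, yet the result stays within the scatter (a 1.3-fold higher number from compound 2 to compound 3 (0.12 log units; within the scatter)). Replacing 4-bromophenyl with 2-fluorophenyl also stays within the scatter (a 1.6-fold lower number from compound 1 to compound 3 (0.21 log units; within the scatter)), so at this place a nitrile is not required for a number in this range. No measurement given here explains these results.

Still open, on these data alone, is how a plain phenyl or a 4-fluorophenyl would read, which would separate the change of group from the change of its place on the ring. Also open, as far as these compounds go, is how an amine or a carboxylic acid on this ring would read.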